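Compound 3 to compound 4: a swap on a carbonyl carbon

This account rests on a few compounds, and the source may have more. Where it says the series, first, only, none or still open, it means among the compounds named here.

In an ADME assay on SH-SY5Y cells (Homo sapiens) for cytotoxicity, read by MTT assay, with a stated time of 48 h (a lower number here means a stronger inhibitor, a higher number a weaker inhibitor), compound 3 `COc1ccc(C(=O)/C=C/c2ccc(C(=O)N(C)c3ccccc3)cc2)c(O)c1` gives > 100000 nM, which is a limit and not a number. Compound 1 `COc1ccc(C(=O)/C=C/c2ccc(C(=O)N3CCCC3)cc2)c(O)c1` gives > 100000 nM, also a limit. Compound 2 `COC(=O)c1ccc(/C=C/C(=O)c2ccc(OC)cc2O)cc1` gives > 100000 nM, again a limit. Going by the values given here, the whole picture is therefore the limit of > 100000 nM in this assay, at which 3 of the 3 values shown sit, and no measured step has a size. The two nearest are a step that the two limits leave unreadable from compound 1 to compound 3 and a step that the two limits leave unreadable from compound 2 to compound 3, and a step that the two limits leave unreadable from compound 1 to compound 2 tells no more.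

Compound 4 `COc1ccc(C(=O)/C=C/c2ccc(C(=O)Nc3ccc(C)cc3C)cc2)c(O)c1` places (2,4-dimethylphenyl)amino where compound 3 has methyl(phenyl)amino on a carbonyl carbon, a change counted as (2,4-dimethylphenyl)amino in place of methyl(phenyl)amino on a carbonyl carbon here. With no readable step to carry over, the expected change is a number no higher from compound 3 to compound 4 (the limit leaves the size open) and nothing beyond the scatter. For compound 4 the estimate is 100000 nM within an expected range of 50000 nM to 200000 nM and the result may well be only a limit again.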

Compound 4, half-maximal inhibitory concentration: > 100000 nM
Compound 4: a limit, no number; the forecaster's own chance of this, stated with the estimate: 75%; the middle value sits exactly at the limit.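

Compound 4 also gives only a limit and not a number, so the steps to it from compound 1, compound 2 and compound 3 cannot be read: the limit of > 100000 nM in this assay, at which 4 of the 4 values shown sit. The compounds shown leave open whether any group on this carbonyl carbon gives a true number in this assay.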